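Working notes: removing one methoxy from compound 2

The compounds below may be only part of what the source reports. "The series", "measured", "known", "first", "only" and "open" are said of these compounds alone.

Compound 1 `COc1cc(-c2cc(/C=C/C(=O)c3ccc(N)cc3)[nH]n2)cc(OC)c1OC` in a functional assay on OVCAR-3 cells (Homo sapiens) for inhibition, read by sulforhodamine B assay, with a stated time of 48 h; on this read-out lower numbers stand for higher toxicity in this test and higher numbers for lower toxicity in this test: 7260 nM
Compound 2 `COc1ccc(C(=O)/C=C/c2cc(-c3cc(OC)c(OC)c(OC)c3)n[nH]2)cc1OC` in this assay: 5970 nM

Among the measured compounds shown here, compound 2 has the lower of the two numbers, but the only measured step, a 1.2-fold lower number from compound 1 to compound 2 (0.08 log units; within the scatter), lies within the scatter, so the two compounds are not separable. Compound 3 `COc1ccc(C(=O)/C=C/c2cc(-c3cc(OC)c(OC)c(OC)c3)n[nH]2)cc1` differs from compound 2 by hydrogen in place of methoxy on an aromatic carbon. For the measured compounds named here, the one measured step bearing on this region, the exchange of the whole aryl on the carbonyl carbon, gave no change beyond the scatter, so no step beyond the scatter is expected in this assay either way. Compound 3 is expected at 6500 nM, between 2500 nM and 17000 nM. That estimate means a step of a 1.1-fold higher number from compound 2 to compound 3 (0.04 log units; within the scatter).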

Compound 3, concentration lethal to 50% of the cells: 7270 nM
Beside the measured number, compound 3's estimate is 1.1-fold (0.05 log units) below it; the range from low to high includes it.
By their numbers in this assay, from the lowest: compounds 2, 1 and 3 (each within the scatter of the next).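

Removing the methoxy ortho to a methoxy group gives a 1.2-fold higher number from compound 2 to compound 3 (0.09 log units; within the scatter) in this assay and so leaves the number within the scatter. The 4-methoxyphenyl of compound 3 also matches the 4-aminophenyl of compound 1, with methoxy in place of amino giving a 1.0-fold higher number from compound 1 to compound 3 (0.00 log units; within the scatter) and thus no separation. Nothing available explains this flat response on the aryl at the carbonyl carbon.

Going by these compounds, whether a carboxylic acid or a chlorine on this aryl would move the number beyond the scatter remains open, as does the effect of an unsubstituted phenyl there.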